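From a Cinnamyl Ether to a Prenyl Ether on the Core

The source may hold more compounds than are shown below. What is called first, only, known or untested is meant among the compounds shown, and "the series" means these compounds.

Of the compounds shown here, two sharing one core have been tested in a functional assay on MCF7 cells (Homo sapiens), tested at 7.5 uM; on this read-out lower numbers stand for a stronger effect and higher numbers for a weaker effect at the one concentration tested. Compound 1, `CC(C)=CCOc1c(C)c(C)c2c(c1C)CCC(C)(COc1ccc(/C=C3\SC(=O)NC3=O)cc1-c1ccc(F)cc1)O2`, gives 85% in this assay. Compound 2, `Cc1c(C)c2c(c(C)c1OC/C=C/c1ccccc1)CCC(C)(COc1ccc(/C=C3\SC(=O)NC3=O)cc1)O2`, gives 43% in this assay, the lowest of the two numbers; its nearest neighbour is compound 1, which sits higher by a gap that lies beyond the usual scatter. Compound 3, `CC(C)=CCOc1c(C)c(C)c2c(c1C)CCC(C)(COc1ccc(/C=C3\SC(=O)NC3=O)cc1)O2`, has not yet been measured. It differs from compound 2 in one place: 2-methylprop-1-en-1-yl in place of 2-phenylethenyl on a saturated chain carbon bound to an oxygen on an aromatic ring. Within the data shown here, no measured pair shows this exact change by itself, so its effect in this assay is open. Among the measured compounds shown here, the only hint comes from compound 1, which also carries the 3-methylbut-2-en-1-yl ether and gives 85%, yet compound 1 differs from compound 2 in another place as well, so its number cannot be read as the effect of this change alone. A moderate rise in the read-out, a move toward a weaker effect, is expected, a step of a number 17 percentage points higher from compound 2 to compound 3 (beyond the scatter). Compound 3 is estimated at 60%, with a range from 40% to 85%.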

Compound 3, a percentage reported as activity, at one concentration (the size of the read-out at that concentration, not a potency): 5%
Beside the measured number, compound 3's estimate is 55 percentage points above it, outside the stated range (below it).
By their numbers in this assay, from the lowest: compound 3; then compound 2; then compound 1.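

In this assay, replacing the (3-phenylprop-2-en-1-yl)oxy group with the (3-methylbut-2-en-1-yl)oxy group gives a number 38 percentage points lower from compound 2 to compound 3 (beyond the scatter) and shows that the group on this saturated chain carbon bound to an oxygen on an aromatic ring strongly affects the read-out, with the ringless 2-methylprop-1-en-1-yl end giving the stronger effect of this pair. The second step, hydrogen in place of 4-fluorophenyl on an aromatic carbon, gives a number 80 percentage points lower from compound 1 to compound 3 (beyond the scatter) and shows that the weak effect of compound 1 cannot be assigned to its (3-methylbut-2-en-1-yl)oxy group, since compound 3 carries the same group and has the strongest effect of the three compounds. Nothing available here explains why either change moves the read-out so far.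

The compounds shown leave open how the read-out would respond to other groups at this ether, such as a plain methyl, a longer chain like geranyl, or a chain ending in an amine or a carboxylic acid. Among these compounds, they also leave open whether 4-fluorophenyl would produce a similar step in a compound carrying the 3-phenylprop-2-en-1-yl ether, since the one step with that change has the 3-methylbut-2-en-1-yl ether in both compounds.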